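Thiazole carboxamides on indole: two weak cytotoxicity values

A few compounds are considered here, and "the series" means these few. Any claim that something is new, unique, unknown or untested is made for them only; others in the source may bear on it.

Measured so far:
compound 1 `COc1ccc2[nH]cc(-c3nc(C(=O)Nc4cc(OC)c(OC)c(OC)c4)cs3)c2c1` gives 84800 nM
compound 2 `O=C(Nc1ccccc1)c1csc(-c2cn(Cc3ccc(Cl)cc3)c3ccccc23)n1` gives 68900 nM

Both numbers come from a functional assay on LNCaP cells (Homo sapiens) for cytotoxicity, read by MTT assay, with a stated time of 48 h, in the presence of a further agent that is not named here; on this read-out lower numbers stand for stronger inhibition and higher numbers for weaker inhibition. Compound 2 has the lowest of the two numbers, but compound 1 sits within the scatter of it, so neither is separated from the other.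

Compound 3 `COc1cc(NC(=O)c2csc(-c3cn(Cc4ccc(Cl)cc4)c4ccccc34)n2)cc(OC)c1OC` is not yet measured. It differs from compound 2 by 3,4,5-trimethoxyphenyl in place of phenyl on an amide-type nitrogen. Among the measured compounds shown here, no measured pair isolates this change, so there is no step in this assay to lean on; compound 1, which already carries the 3,4,5-trimethoxyphenyl, shows no separation from compound 2. For compound 3 a step of a 1.0-fold higher number from compound 2 to compound 3 (0.01 log units; within the scatter) is expected, that is, none beyond the scatter. Compound 3 is thus estimated at 70000 nM, with a range from 30000 nM to 160000 nM.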

Compound 3, half-maximal inhibitory concentration: > 100000 nM
Compound 3 gave a limit, no number; the forecaster's own chance of this, stated with the estimate: 15%; at least 1.4-fold (0.15 log units) between middle value and limit.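

Compound 3 reads > 100000 nM, which is a limit and not a number. With the rest of the structure held, 3,4,5-trimethoxyphenyl in place of phenyl on an amide-type nitrogen gives an at least 1.4-fold higher number from compound 2 to compound 3 (0.16 log units; that floor lies within the scatter), so this change shows no stronger inhibition and its true size stays unread. The reading ends at the limit of the assay: the limit of > 100000 nM in this assay, at which 1 of the 3 values shown sits.

Only phenyl and 3,4,5-trimethoxyphenyl are shown on this nitrogen. As far as these compounds go, how an amine or a carboxylic acid in place of phenyl on an amide-type nitrogen would read remains open.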